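Replacing chloro with trifluoromethyl on a chalcone-like scaffold

The compounds below may be only part of what the source reports. "The series", "measured", "known", "first", "only" and "open" are said of these compounds alone.

Measured so far:
compound 1, `COc1cc(O)c(CC=C(C)C)c(O)c1C(=O)/C=C/c1ccc(O)c(O)c1`, 16100 nM
compound 2, `COc1ccccc1/C=C/C(=O)c1c(OC)cc(O)c(CC=C(C)C)c1O`, 12500 nM
compound 3, `COc1cc(O)c(CC=C(C)C)c(O)c1C(=O)/C=C/c1ccc(Cl)cc1`, 11800 nM

These three compounds share a common core and differ only in the aromatic ring attached to the double-bonded chain carbon. In a functional assay on A549 cells (Homo sapiens) for inhibition, read by MTT assay, with a stated time of 72 h (on this read-out lower numbers stand for stronger inhibition and higher numbers for weaker inhibition), compound 1 gives 16100 nM, compound 2 gives 12500 nM and compound 3 gives 11800 nM. Compound 3 gives the lowest of the three numbers, but its distance to the others is small: a 1.1-fold lower number from compound 2 to compound 3 (0.03 log units; within the scatter) and a 1.4-fold lower number from compound 1 to compound 3 (0.13 log units; within the scatter). Every change of the aromatic ring among these compounds, including a 1.3-fold lower number from compound 1 to compound 2 (0.11 log units; within the scatter), stayed within the scatter.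

Compound 4, `COc1cc(O)c(CC=C(C)C)c(O)c1C(=O)/C=C/c1ccc(C(F)(F)F)cc1`, keeps the core of compound 3 and carries the change (trifluoromethyl in place of chloro on an aromatic carbon). For the measured compounds named here, no measured step swaps these two groups directly; the only steps available are the whole-ring exchanges above, and all of them were flat. Compound 4 is therefore expected to give 12500 nM in this assay, with a range from 6000 nM to 26000 nM. The step of a 1.1-fold higher number from compound 3 to compound 4 (0.03 log units; within the scatter) is thus estimated to be no larger than the scatter, in either direction.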

Compound 4, half-maximal inhibitory concentration: 11100 nM
Compound 4: middle estimate off by 1.1-fold (0.05 log units), on the high side; measured number inside the range.
By their numbers in this assay, from the lowest: compounds 4, 3, 2 and 1 (each within the scatter of the next).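

Putting trifluoromethyl in place of chloro on an aromatic carbon, para to a large group, gives a 1.1-fold lower number from compound 3 to compound 4 (0.03 log units; within the scatter) in this assay, even though the entering group has four heavy atoms and the leaving one has a single heavy atom. The earlier steps shown here exchanged the whole aromatic ring, whereas this one changes a single group on that ring and shows that this swap, too, leaves the number within the scatter, so the larger group is accepted here without a measurable change. Nothing at hand bears on the reason for this flat result.

With all four compounds lying within the scatter of one another, this position has yet to show a step beyond it. Going by these compounds, whether an amine or a carboxylic acid at this same aromatic carbon would move the number beyond the scatter remains open.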